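Methyl Capping of a Phenol and Cell Tolerance

The source may report more compounds than this note shows. Statements on the series, on what has been measured and on what is new or still open speak of the compounds shown alone.

Compound 1 `O=C(Nc1ccccc1)c1cc(Br)ccc1O` serves as the starting point. In an ADME assay on HEK293 cells (Homo sapiens) for cytotoxicity, read by reporter gene assay and resazurin assay, with a stated time of 48 h (a higher number here means that more compound is tolerated, a lower number that less compound is tolerated), compound 1 gives 35000 nM. Compound 2 `COc1ccc(Br)cc1C(=O)Nc1ccccc1` differs from it by one change, (methyl in place of hydrogen on an oxygen on an aromatic ring). In this assay compound 2 reaches only a limit of the measurement, > 100000 nM. The measured step is an at least 2.8-fold higher number from compound 1 to compound 2 (0.45 log units; beyond the scatter), and its exact size is cut off by the limit of > 100000 nM in this assay, at which 1 of the 3 values shown sits.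

Compound 3 `O=C(Nc1ccc(Sc2nc3ccccc3s2)cc1)c1cc(Br)cc(Br)c1O` carries a larger, different framework; how its core differs from the core of compound 1 is not broken down here. In this assay compound 3 gives 66000 nM. Compound 3 and compound 1 stand within the scatter of each other, so no order between them is claimed.

Compound 4 `COc1c(Br)cc(Br)cc1C(=O)Nc1ccc(Sc2nc3ccccc3s2)cc1` has not yet been measured. It differs from compound 3 by methyl in place of hydrogen on an oxygen on an aromatic ring. The place of this change reads the same, word for word, as the place of the change from compound 1 to compound 2, so it is the same change, seen for the second time among these compounds.

For compound 4 the change is expected to make a step of a 2.3-fold higher number from compound 3 to compound 4 (0.36 log units; beyond the scatter), because the same change gave an at least 2.8-fold higher number from compound 1 to compound 2 (0.45 log units; beyond the scatter). Since compound 3 already sits close to the upper edge of this assay, the result for compound 4 may again be reported only as a limit. Compound 4 is therefore estimated at 150000 nM, with a likely range from 70000 nM to 300000 nM.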

Compound 4, half-maximal cytotoxic concentration: > 100000 nM
Compound 4 was reported as a limit; the forecaster's own chance of this, stated with the estimate: 65%; the middle value does not contradict the limit.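

In this assay, methoxy in place of hydroxy on the larger framework gives an at least 1.5-fold higher number from compound 3 to compound 4 (0.18 log units; that floor lies within the scatter), and only this floor can be read, as compound 4 is reported as a limit and not as a number. The result fits a change that carries over from one core to the other, since nothing in it runs against the earlier step, but it does not show that the step on the second core lies beyond the scatter, nor that the two steps are of the same size: the same change on two cores in this assay, an at least 2.8-fold higher number (0.45 log units; beyond the scatter) from compound 1 to compound 2 and an at least 1.5-fold higher number (0.18 log units; that floor lies within the scatter) from compound 3 to compound 4; the limit leaves it open whether they differ. From the compounds shown here alone, neither capped compound gives an exact value, so the true size of the step remains unknown on both cores, and the series offers no case in which the change can be measured in full: the limit of > 100000 nM in this assay, at which 2 of the 4 values shown sit.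

The compounds shown leave open whether a longer chain on that oxygen, or an amine in place of the hydroxy group, would give a value that can be read as a number in this measurement. They also leave open how far the true values of compound 2 and compound 4 lie past their limits.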